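Swapping Nitro for Trifluoromethyl on a Second Core

A few compounds are considered here, and "the series" means these few. Any claim that something is new, unique, unknown or untested is made for them only; others in the source may bear on it.

Of the compounds shown here, three have so far been measured in a functional assay on A2780 cells (Homo sapiens) for inhibition, with a stated time of 72 h; a lower number here means a stronger inhibitor, a higher number a weaker inhibitor. Compound 1 `CCC1(CC)CC(CC)(CC)c2cc(NC(=O)Nc3ccc(C(F)(F)F)cc3)ccc2O1` gives 2000 nM, compound 2 `CCC1(CC)CC(CC)(CC)c2cc(NC(=O)Nc3ccc([N+](=O)[O-])cc3)ccc2O1` gives 2090 nM, and compound 3 `CCC1(CC)CC(C)(C)Oc2ccc(NC(=S)Nc3ccc([N+](=O)[O-])cc3)cc21` gives 3690 nM. Compound 1 and compound 2 share one core and differ in a single place, (trifluoromethyl in place of nitro on an aromatic carbon); the step is a 1.0-fold lower number from compound 2 to compound 1 (0.02 log units; within the scatter). Compound 3 stands on a different core, and the difference between the two cores is not broken down here; its number sits within the scatter of both compound 1 and compound 2.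

Compound 4 `CCC1(CC)CC(C)(C)Oc2ccc(NC(=S)Nc3ccc(C(F)(F)F)cc3)cc21` has not yet been measured. Among the measured compounds shown here, it differs from compound 3 by trifluoromethyl in place of nitro on an aromatic carbon, which is the same change as the one from compound 2 to compound 1, made at the same kind of position. For the measured compounds named here, the only guide to its size is the step already seen, and on that basis the estimate for compound 4 in this assay means a 1.0-fold lower number from compound 3 to compound 4 (0.01 log units; within the scatter), because the earlier step of a 1.0-fold lower number from compound 2 to compound 1 (0.02 log units; within the scatter) stayed within the scatter. Whether the change reads the same way on the core of compound 3 cannot be checked from what is shown, so the range is kept wide. Compound 4 is thus estimated at 3600 nM, expected between 1800 nM and 7500 nM.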

Compound 4, half-maximal inhibitory concentration: 4700 nM
Beside the measured number, compound 4's estimate is 1.3-fold (0.12 log units) below it; the range from low to high includes it.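

In this assay, the exchange of nitro for trifluoromethyl on the second core gives a 1.3-fold higher number from compound 3 to compound 4 (0.11 log units; within the scatter), so on this core too the number stays within the scatter. Set beside the earlier step, the new one does not differ from it: the same change on two cores in this assay, a 1.0-fold lower number (0.02 log units; within the scatter) from compound 2 to compound 1 and a 1.3-fold higher number (0.11 log units; within the scatter) from compound 3 to compound 4, 1.3-fold (0.12 log units) apart, within the scatter of two such steps. For these two pairs, then, 4-nitrophenyl and 4-(trifluoromethyl)phenyl can be exchanged on either core with no change beyond the scatter, but this is a match between two small steps, and it does not show that a larger step would carry over, that the same would hold on any further core, or that it would hold in any other assay.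

The compounds shown leave open what other groups in this place would do on either core, such as a chlorine, a methoxy group, an amine or a carboxylic acid. Among the compounds shown here, they also leave open what the difference between the two cores contributes by itself, as that difference spans more than one place and no pair here takes it apart.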